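Methyl Additions on Two Cores of the Series

The compounds below may be only part of what the source reports. "The series", "measured", "known", "first", "only" and "open" are said of these compounds alone.

Measured so far in a functional assay for inhibition, with Homo sapiens as the target; a lower number here means a stronger inhibitor, a higher number a weaker inhibitor:
- compound 1 `Cc1cc(C)cc(Nc2nccc(-c3cccnc3)n2)c1` gives 800 nM
- compound 3 `CCN(CC)c1ccc(Nc2nccc(-c3ccco3)n2)cc1` gives 8700 nM
- compound 2 `Cc1cc(C)cc(Nc2ncc(C)c(-c3cccnc3)n2)c1` gives only a limit, > 24000 nM

Compound 2 differs from compound 1 by methyl in place of hydrogen on an aromatic carbon. That change brings an at least 30-fold higher number from compound 1 to compound 2 (1.47 log units; beyond the scatter), and compound 2 sits at the limit of > 24000 nM in this assay, at which 1 of the 3 values shown sits, so the true extent of the loss is not known.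

Compound 3 carries a different core. How that core differs from the core of compound 1 is not broken down here; the two values simply show compound 3 with the higher number of the two in this assay.

Compound 4 `CCN(CC)c1ccc(Nc2nccc(-c3ccc(C)o3)n2)cc1` is now to be measured. It differs from compound 3 by methyl in place of hydrogen on an aromatic carbon. This is the same kind of change as from compound 1 to compound 2, but not the same: there the methyl entered on a six-membered aromatic ring with 2 nitrogen, ortho to a pyridin-3-yl group; here it enters on a five-membered aromatic ring with 1 oxygen, next to the ring oxygen, two ring bonds from the ring atom that bears a large group.

Given that the one measured instance of this kind of change, an at least 30-fold higher number from compound 1 to compound 2 (1.47 log units; beyond the scatter), was a large loss, a step toward a higher number is expected from compound 3 to compound 4, a 1.7-fold higher number from compound 3 to compound 4 (0.24 log units; within the scatter), though smaller, since the surroundings differ. Compound 4 is expected to give about 15000 nM in this assay, between 5000 nM and 40000 nM, with a real chance that only a limit is reported.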

Compound 4, half-maximal inhibitory concentration: 28000 nM
For compound 4 the middle estimate is 1.9-fold (0.27 log units) below the measured one; low and high end bracket the measured number.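

In this assay the methyl step on the furan-2-yl compound is modest, a 3.2-fold higher number from compound 3 to compound 4 (0.51 log units; beyond the scatter), so the number moves the same way as on the core of compound 1, but the size of the step does not carry over from one core to the other: the same change on two cores in this assay, an at least 30-fold higher number (1.47 log units; beyond the scatter) from compound 1 to compound 2 and a 3.2-fold higher number (0.51 log units; beyond the scatter) from compound 3 to compound 4, at least 9.3-fold (0.96 log units) apart, beyond the scatter of two such steps. As far as these compounds go, compound 2 gives only a limit, > 24000 nM, so the size of the earlier step stays unknown: the limit of > 24000 nM in this assay, at which 1 of the 4 values shown sits. The methyl enters a different ring in each case, and the compounds shown hold no pair that separates the ring carrying the methyl from the rest of the core, so the two steps give a shared direction and no rule for the size of the step on a further core.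

Open, from the compounds shown here alone, is how a longer chain such as ethyl, or an amine, would read in this assay in place of the methyl of the 5-methylfuran-2-yl group. Also open, going by these compounds, is whether a methyl on the pyridin-3-yl group of compound 1 would give a step closer to the modest one or to the large one.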